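The source may hold more compounds than are shown below. What is called first, only, known or untested is meant among the compounds shown, and "the series" means these compounds.

Compound 1, `O=C(CCSc1nc2cc(Cl)ccc2o1)N1CCS(=O)(=O)C1`, carries a chloro-substituted core linked through a saturated chain to an amide of 1,1-dioxo-1,3-thiazolidin-3-yl. In an ADME assay on microsomes from liver (Homo sapiens) for metabolic stability, read by LC-MS, using NADPH, with a stated time of 45 min, tested at 0.5 uM (on this read-out lower numbers stand for slow clearance and higher numbers for fast clearance), compound 1 gives 1.7 mL/min/g, the higher of the two numbers recorded so far. The other measured compound, compound 2, `O=C(CCSc1nc2ncccc2o1)N1CCCC1`, differs in both its core and its amide; in this assay compound 2 gives 0.7 mL/min/g, a value that sits clearly lower than that of compound 1 once the usual scatter is allowed for. Going by the values given here, no single-change step between measured compounds is available, so no direct comparison can be drawn for the change now at hand.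

Compound 3, `CN(C)C(=O)CCSc1nc2cc(Cl)ccc2o1`, is the next compound to be examined. Relative to compound 1 it differs as follows: dimethylamino in place of 1,1-dioxo-1,3-thiazolidin-3-yl on a carbonyl carbon. Because compound 1 already stands at 1.7 mL/min/g, compound 3 is expected to show a modest upward step, a 1.5-fold higher number from compound 1 to compound 3 (0.18 log units; within the scatter), perhaps just beyond the scatter. Compound 3 is thus estimated at 2.6 mL/min/g, with a range from 1.2 mL/min/g to 5.5 mL/min/g.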

Compound 3, intrinsic clearance in a liver preparation (reported as CLH), per the amount of preparation that the assay uses: 2.7 mL/min/g
The estimate for compound 3 lay 1.0-fold (0.02 log units) below the measured number; low and high end bracket the measured number.
By their numbers in this assay, from the lowest: compound 2; then compounds 1 and 3 (each within the scatter of the next).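

In this assay, going by these compounds alone, the change at this carbonyl carbon gives the first single-change step: dimethylamino in place of 1,1-dioxo-1,3-thiazolidin-3-yl gives a 1.6-fold higher number from compound 1 to compound 3 (0.20 log units; within the scatter), with the chloro-bearing core and saturated chain held constant. At this position, therefore, the read-out does not separate the two groups, even though dimethylamino has neither the ring nor the hydrogen-bond acceptors of the group it replaces. Nothing available explains this outcome.

On these data alone, it remains open whether a morpholine or piperidine ring on the same carbonyl carbon, or a secondary amide carrying an amide hydrogen, would fall within the scatter of these two compounds. As far as these compounds go, it is also open whether the same exchange would give a similar step on the core of compound 2.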